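Ester variation on the shared core and plasma half-life

The source may hold more compounds than are shown below. What is called first, only, known or untested is meant among the compounds shown, and "the series" means these compounds.

In an ADME assay on a cell-free system (plasma, Homo sapiens) for metabolic stability, with Plasma (Rattus norvegicus) as the target, read by HPLC, at pH 7.4 (on this read-out higher numbers stand for a longer-lived compound and lower numbers for a shorter-lived compound), compound 1 `CC(=O)Oc1ccccc1C(=O)O[C@H]1CO[C@H]2[C@@H]1OC[C@H]2OC(C)=O` gives 0.0608 h, and compound 2 `CCC(=O)O[C@@H]1CO[C@H]2[C@@H]1OC[C@@H]2OC(=O)c1ccccc1OC(C)=O` gives 0.0608 h, so the two stand level at the lowest of the three numbers; compound 3 `CC(=O)Oc1ccccc1C(=O)O[C@H]1CO[C@H]2[C@@H]1OC[C@H]2OC(=O)c1ccccc1OC(=O)c1ccccc1` gives 0.385 h. The step of no change at the digits printed from compound 1 to compound 2 (within the scatter) shows that enlarging the acyl group by one carbon left this assay unchanged. Compound 4 `CC(=O)Oc1ccccc1C(=O)O[C@H]1CO[C@H]2[C@@H]1OC[C@H]2OC(=O)c1cccnc1` differs from compound 2 by pyridin-3-yl in place of ethyl on a carbonyl carbon. Going by the values given here, no measured step matches an aromatic ring entering at this carbonyl carbon, though compound 3 carries an aromatic ester there and shows the highest of the three numbers. A modest rise is therefore expected, a 2.5-fold higher number from compound 2 to compound 4 (0.39 log units; beyond the scatter), and compound 4 is estimated at 0.15 h, between 0.06 h and 0.4 h.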

Compound 4, half-life: 0.0232 h
Beside the measured number, compound 4's estimate is 6.5-fold (0.81 log units) above it; the measured number lies below the stated range.
By their numbers in this assay, from the lowest: compound 4; then compounds 1 and 2 (each within the scatter of the next); then compound 3.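

In this assay this carbonyl carbon proved sensitive to the group it carries, which the change from methyl to ethyl had not shown: pyridin-3-yl in place of ethyl gives a 2.6-fold lower number from compound 2 to compound 4 (0.42 log units; beyond the scatter), and pyridin-3-yl in place of methyl gives a 2.6-fold lower number from compound 1 to compound 4 (0.42 log units; beyond the scatter). An aromatic ring here does not go with a longer half-life in every case, as compound 4 gives 0.0232 h and compound 3 gives 0.385 h. Nothing available accounts for the shorter half-life of compound 4. The compounds shown leave open whether the ring nitrogen of pyridin-3-yl matters, which an unsubstituted phenyl on this carbonyl carbon would help to settle. As far as these compounds go, how a longer chain or an amine would fare at this place also remains open.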